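A few compounds are considered here, and "the series" means these few. Any claim that something is new, unique, unknown or untested is made for them only; others in the source may bear on it.

Measured in a functional assay on HeLa cells (Homo sapiens) for antiproliferative activity, read by sulforhodamine B assay, with a stated time of 48 h; a higher number here means a weaker inhibitor, a lower number a stronger inhibitor:

- compound 1 `COc1cc(C(=O)/C=C\Nc2ccc(-c3nc4cc(OC)c(OC)c(OC)c4s3)cc2)c(Br)c(OC)c1OC`: 6600 nM
- compound 2 `COc1cc(C(=O)/C=C\Nc2ccc(-c3nc4cc(OC)c(OC)c(OC)c4s3)cc2C)c(Br)c(OC)c1OC`: 14300 nM
- compound 3 `COc1cc(OC)c2sc(-c3ccc(N/C=C\C(=O)c4cc(OC)c(OC)c(OC)c4Br)cc3)nc2c1`: 10300 nM

Two measured steps show where compound 1 stands. The first (a 1.6-fold higher number from compound 1 to compound 3 (0.19 log units; within the scatter)) does not separate the pair. The second (a 2.2-fold higher number from compound 1 to compound 2 (0.34 log units; beyond the scatter)) is modest and leaves compound 2 clearly on the weaker side.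

Compound 4 `COc1cc(C(=O)/C=C\Nc2ccc(-c3nc4cc(OC)c(OC)c(OC)c4s3)cc2)cc(OC)c1OC` has not been measured. It is compound 1 with hydrogen in place of bromo on an aromatic carbon.

Neither measured step touches that bromo group. One adds a methyl on an aromatic carbon, and the other puts hydrogen in place of methoxy on an aromatic carbon. Together they show only that single changes to compound 1 have so far moved the number modestly or less. No measurement isolates the bromo group, so no direction can be read from these data, and no step beyond the scatter is expected in this assay, though with wide uncertainty. The expected change is small (a 1.1-fold lower number from compound 1 to compound 4 (0.04 log units; within the scatter)). The estimate for compound 4 is 6000 nM, with an expected range from 1500 nM to 20000 nM.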

Compound 4, half-maximal inhibitory concentration: 5300 nM
The estimate for compound 4 lay 1.1-fold (0.05 log units) above the measured number; low and high end bracket the measured number.
By their numbers in this assay, from the lowest: compounds 4, 1, 3 and 2 (each within the scatter of the next, the first and the last beyond it).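

In this assay, among these compounds, the exchange of bromo for hydrogen is the first measured step at this position, and the step of a 1.2-fold lower number from compound 1 to compound 4 (0.10 log units; within the scatter) does not separate the pair. On this aromatic carbon, ortho to a large group and ortho to a methoxy group, the bromo group is therefore not required for compound 4 to read alongside compound 1. No evidence is available on why the two compounds read alike.

Only bromo and hydrogen appear at this position among the compounds shown, so it remains open whether an amine, a hydroxyl group or a longer chain there would move the number. From the compounds shown here alone, it also remains open whether the methyl and methoxy steps seen with the bromo group in place would read the same with hydrogen there.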